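Working notes on a small cytotoxicity series

The source may report more compounds than this note shows. Statements on the series, on what has been measured and on what is new or still open speak of the compounds shown alone.

Measured compounds:
compound 1, `COc1ccc(-c2cc(/C=C/C(=O)c3ccc(N)cc3)[nH]n2)cc1`: -94%
compound 2, `COc1ccc(-c2cc(/C=C/C(=O)c3ccc(N)cc3)[nH]n2)cc1OC`: -92%
compound 3, `COc1cc(C(=O)/C=C/c2cc(-c3cc(OC)c(OC)c(OC)c3)n[nH]2)cc(OC)c1OC`: -99%

In a functional assay on SF-539 cells (Homo sapiens) for cytotoxicity, read by sulforhodamine B assay, with a stated time of 48 h, tested at 100 uM (on this read-out lower numbers stand for a stronger effect and higher numbers for a weaker effect at the one concentration tested), compound 1 gives -94%, compound 2 gives -92% and compound 3 gives -99%. All three numbers sit close together. The change from compound 2 to compound 1 is hydrogen in place of methoxy on an aromatic carbon, and in this assay it makes a number 2 percentage points lower from compound 2 to compound 1 (within the scatter). The difference between the core of compound 2 and the core of compound 3 is not broken down here.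

Compound 4, `COc1ccc(-c2cc(/C=C/C(=O)c3cc(OC)c(OC)c(OC)c3)[nH]n2)cc1OC`, is not yet measured. It differs from compound 3 by hydrogen in place of methoxy on an aromatic carbon. The surroundings are not word for word the same as from compound 2 to compound 1: in compound 3 the place is also meta to a methoxy group, so this is the same kind of change rather than the same one.

In this assay the step is expected to be small, a number 2 percentage points higher from compound 3 to compound 4 (within the scatter), because it rests on a number 2 percentage points lower from compound 2 to compound 1 (within the scatter), which was within the scatter. Compound 4 is therefore estimated at -97%, expected to fall between -100% and -88%.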

Compound 4, a percentage reported as activity, at one concentration (the size of the read-out at that concentration, not a potency): -87%
Compound 4: middle estimate off by 10 percentage points, on the low side; measured number above the stated range.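

In this assay, putting hydrogen in place of methoxy on an aromatic carbon gives a number 12 percentage points higher from compound 3 to compound 4 (beyond the scatter), a modest step. Set beside the earlier case, the two steps cannot be told apart, so the series gives no sign that this change acts differently on the two cores: the same change on two cores in this assay, a number 2 percentage points lower (within the scatter) from compound 2 to compound 1 and a number 12 percentage points higher (beyond the scatter) from compound 3 to compound 4, 14 percentage points apart, within the scatter of two such steps This does not show that the step is the same on both cores, as only two pairs stand behind the comparison, with one step within the scatter and the other beyond it.

The compounds shown leave open how other groups would read at this aromatic carbon, such as a hydroxyl, a chlorine or an ethoxy group in place of the methoxy. Also open, as far as these compounds go, is whether removing a different methoxy group from these cores would give a step of similar size.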